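Compound 3 to 4: Swapping Trifluoromethyl for Trifluoromethoxy

This account rests on a few compounds, and the source may have more. Where it says the series, first, only, none or still open, it means among the compounds named here.

In a functional assay on HeLa cells (Homo sapiens) for cytotoxicity, read by MTT assay, with a stated time of 2 days (a higher number here means a weaker inhibitor, a lower number a stronger inhibitor), compound 1 `Cc1cccc(-c2nc3ccc(C)cc3c(=O)[nH]2)c1` gives > 50000 nM, which is a limit of the assay. Compound 3 `Cc1ccc2nc(-c3cccc(C(F)(F)F)c3)[nH]c(=O)c2c1` gives > 50000 nM, which is also a limit. Among the measured compounds shown here, compound 2 `Cc1ccc2c(=O)[nH]c(-c3ccccc3OC(F)(F)F)nc2c1`, the only measured compound carrying trifluoromethoxy, reads 18300 nM, though it differs from compound 3 elsewhere too. Compound 4 `Cc1ccc2nc(-c3cccc(OC(F)(F)F)c3)[nH]c(=O)c2c1` carries trifluoromethoxy in place of trifluoromethyl on an aromatic carbon, meta to a large group (trifluoromethoxy in place of trifluoromethyl on an aromatic carbon). For the measured compounds named here, the one measured step bearing on this, a step that the two limits leave unreadable from compound 1 to compound 3, offers no size, and the series shows (the limit of > 50000 nM in this assay, at which 2 of the 3 values shown sit). Only a weak pull from compound 2 at 18300 nM suggests any gain in this assay. The expected change is an at least 1.1-fold lower number from compound 3 to compound 4 (0.04 log units; that floor lies within the scatter), small and toward stronger inhibition if it can be read at all. For compound 4 the estimated value is 45000 nM, within an expected range of 18000 nM to 80000 nM.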

Compound 4, half-maximal inhibitory concentration: > 50000 nM
Compound 4 gave a limit, no number; the forecaster's own chance of this, stated with the estimate: 60%; middle value at least 1.1-fold (0.04 log units) from the limit.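

In this assay compound 4 gives > 50000 nM, which is a limit of the assay. Among the compounds shown here, no step among compound 1, compound 3 and compound 4 can be read. The compounds shown leave open whether trifluoromethoxy in place of trifluoromethyl changes the reading at all, and the series stays at one mark: the limit of > 50000 nM in this assay, at which 3 of the 4 values shown sit.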